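Swapping a Nitro Group for Methoxy in a Cytotoxicity Series

This account rests on a few compounds, and the source may have more. Where it says the series, first, only, none or still open, it means among the compounds named here.

Compound 2 `COc1cc(NC(=O)Nc2ccc([N+](=O)[O-])cc2)cc(OC)c1OC` is the only one of the three with a full number in a functional assay on Daoy cells (Homo sapiens) for cytotoxicity, read by MTT assay, with a stated time of 72 h (a higher number here means a weaker inhibitor, a lower number a stronger inhibitor), where compound 2 gives 70800 nM. Compound 1 `COc1cc(NC(=O)c2ccc(F)cc2)cc(OC)c1OC` reaches only the limit of this assay, >= 125000 nM, which is a boundary rather than a measured number. For compound 3 `COc1cc(N(C)C(=O)N(C)c2ccccc2)cc(OC)c1OC` the entry in this assay is "not determined" (no result reported), so no result is reported. The step to compound 4 `COc1ccc(NC(=O)Nc2cc(OC)c(OC)c(OC)c2)cc1` changes one group: methoxy in place of nitro on an aromatic carbon. Going by the values given here, no measured pair in this set shows such a change, so nothing tells how large its effect might be. Resting only on compound 2 at 70800 nM, the expectation is a step of a 1.3-fold higher number from compound 2 to compound 4 (0.10 log units; within the scatter), small enough to sit within the usual scatter. Compound 4 is therefore estimated at 90000 nM, between 35000 nM and 250000 nM.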

Compound 4, half-maximal inhibitory concentration: 14900 nM
Estimate against measurement, compound 4: 6.0-fold (0.78 log units) above, outside the stated range (below it).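

Methoxy in place of nitro, on an aromatic carbon para to a large group, gives a 4.8-fold lower number from compound 2 to compound 4 (0.68 log units; beyond the scatter) in this assay, so what this position carries does change the result. Both ends of that step are full numbers, which gives this series its first measured comparison. Compound 1 stands at a limit of the assay, not a number: the limit of >= 125000 nM in this assay, at which 1 of the 4 values shown sits.

The compounds shown leave open how an amine, a carboxylic acid or a longer chain would compare at this position. Two groups alone cannot show whether the number would fall further.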